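Trifluoromethyl for methylsulfonyl on a weakly active scaffold

This account rests on a few compounds, and the source may have more. Where it says the series, first, only, none or still open, it means among the compounds named here.

Measured in an ADME assay on WI-38 cells (Homo sapiens) for inhibition, read by CellTiter-Glo, with a stated time of 4 days; on this read-out higher numbers stand for weaker inhibition of growth and lower numbers for stronger inhibition of growth:
compound 1, `Clc1cc(-c2ccccc2)nn1-c1ccccn1`: > 30000 nM, a limit of the assay rather than a number
compound 2, `CS(=O)(=O)c1ccc(-n2nc(-c3ccccc3)cc2O)nc1`: > 30000 nM, again a limit rather than a number
compound 3, `Cc1ccc(-n2nc(-c3ccccc3)cc2O)nc1`: 26300 nM; > 12000 nM (2 entries), given as several entries

Compound 2 therefore stands at the top of what this assay reports: for compound 2 only a limit is known, and it shares that limit with compound 1, as the limit of > 30000 nM in this assay, at which 2 of the 3 values shown sit, shows. Going by the values given here, compound 3 is the only one with a single number, and its repeated entries, (the several entries of compound 3 in this assay, 26300 nM; > 12000 nM (2 entries)), sit in the same weak region, so all three compounds show little growth inhibition.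

Compound 4, `Oc1cc(-c2ccccc2)nn1-c1ccc(C(F)(F)F)cn1`, differs from compound 2 in one place: trifluoromethyl in place of methylsulfonyl on an aromatic carbon. Among the compounds with values here, no measured pair shows what such a swap does here, so no step beyond the scatter is expected in either direction in this assay; compound 4 is estimated to remain at or near the limit, the expected step from compound 2 to compound 4 being a number no higher from compound 2 to compound 4 (the limit leaves the size open). Compound 4 is thus expected to give about 30000 nM, within 10000 nM to 100000 nM.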

Compound 4, concentration for 50% growth inhibition: 9400 nM
The estimate for compound 4 lay 3.2-fold (0.50 log units) above the measured number; measured number below the stated range.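

In this assay, placing trifluoromethyl instead of methylsulfonyl on this aromatic carbon, two atoms from the ring nitrogen, gives an at least 3.1-fold lower number from compound 2 to compound 4 (0.50 log units; beyond the scatter), so this position can change the read-out by more than the usual scatter. Compound 2 has only a limit, > 30000 nM, so the step gives a minimum size rather than an exact one. Such limits make up much of this small set, and the earlier compounds alone gave no measured step at this position: the limit of > 30000 nM in this assay, at which 2 of the 4 values shown sit.

The compounds shown leave open whether a nitrile, an amine or a carboxylic acid on the same carbon would lower the number further or raise it again. They also leave open whether the same swap would have a similar effect on a different core.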